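Fluorophenyl swap on compound 1

A few compounds are considered here, and "the series" means these few. Any claim that something is new, unique, unknown or untested is made for them only; others in the source may bear on it.

In a functional assay on KB cells (Homo sapiens) for cytotoxicity, read by sulforhodamine B assay (on this read-out lower numbers stand for stronger inhibition and higher numbers for weaker inhibition), compound 1 (`C=C1[C@@H](OC(C)=O)C[C@@H]2[C@](C)(COC=O)[C@H](OC(C)=O)CC[C@@]2(C)[C@@H]1C[C@@H](Nc1cccc(F)c1)C1=CCOC1=O`) gives 28600 nM, the highest of the three numbers in hand. Compound 2 (`C=C1CC[C@@H]2[C@](C)(CO[Si](C)(C)C(C)(C)C)[C@H](OC(C)=O)CC[C@@]2(C)[C@@H]1C/C=C1/C(=O)OC[C@H]1OC(C)=O`) gives 5050 nM and compound 3 (`C=C1[C@@H](OC(C)=O)C[C@@H]2[C@](C)(CO[Si](C)(C)C(C)(C)C)[C@H](OC(C)=O)CC[C@@]2(C)[C@@H]1C[C@@H](Nc1cccc(F)c1)C1=CCOC1=O`) gives 4560 nM. Compound 4 (`C=C1[C@@H](OC(C)=O)C[C@@H]2[C@](C)(COC=O)[C@H](OC(C)=O)CC[C@@]2(C)[C@@H]1C[C@@H](Nc1ccc(F)cc1)C1=CCOC1=O`) differs from compound 1 by 4-fluorophenyl in place of 3-fluorophenyl on an amine nitrogen, with 4-fluorophenyl in place of 3-fluorophenyl on an amine nitrogen. For the measured compounds named here, the only measured step, a 6.3-fold lower number from compound 1 to compound 3 (0.80 log units; beyond the scatter), is a change on an oxygen on a saturated carbon and leaves the 3-fluorophenyl untouched. Going by the values given here, no measured pair tests the fluorophenyl group, so no step beyond the scatter is expected in this assay, and neither direction is favoured. For compound 4 the estimated value is 26000 nM, with an expected range of 11000 nM to 60000 nM. The expected change is a 1.1-fold lower number from compound 1 to compound 4 (0.04 log units; within the scatter).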

Compound 4, half-maximal inhibitory concentration: 22900 nM
Compound 4: middle estimate off by 1.1-fold (0.06 log units), on the high side; measured number inside the range.
By their numbers in this assay, from the lowest: compounds 3 and 2 (each within the scatter of the next); then compounds 4 and 1 (each within the scatter of the next).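

In this assay, for the compounds shown here, 4-fluorophenyl in place of 3-fluorophenyl on an amine nitrogen gives a 1.2-fold lower number from compound 1 to compound 4 (0.10 log units; within the scatter) and is the first measured test of this group. Where the fluorine sits on the phenyl ring therefore makes no difference beyond the scatter in this pair, while the change on the oxygen, a 6.3-fold lower number from compound 1 to compound 3 (0.80 log units; beyond the scatter), remains the only step in the series beyond it. Open, as far as these compounds go, is whether an unsubstituted phenyl, a pyridine ring or a benzyl group on that nitrogen would give a step beyond the scatter, and whether the fluorine swap would read the same with the group of compound 3 on the oxygen. No evidence on hand explains either step.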